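The compounds below may be only part of what the source reports. "The series", "measured", "known", "first", "only" and "open" are said of these compounds alone.

Measured in a functional assay on HCT-116 cells (Homo sapiens) for antiproliferative activity, read by MTT assay, with a stated time of 24 h; a lower number here means a stronger inhibitor, a higher number a weaker inhibitor:
- Compound 1 `COc1ccc(C(=O)/C=C/c2ccc(F)cc2)c2c1C=CC(C)(C)O2`: > 10000 nM
- Compound 2 `COc1ccc(C(=O)/C=C/c2ccccc2)c2c1C=CC(C)(C)O2`: > 10000 nM
- Compound 3 `COc1ccc(C(=O)/C=C/c2ccccn2)c2c1C=CC(C)(C)O2`: 6630 nM

Compound 1 reads > 10000 nM, which is a limit and not a number. Compound 2 reads > 10000 nM, also a limit. Among the compounds with values here, compound 3, at 6630 nM, holds the only actual number in the set.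

Compound 4 `COc1ccc(C(=O)/C=C/c2ccc(Cl)cc2)c2c1C=CC(C)(C)O2` differs from compound 3 by 4-chlorophenyl in place of pyridin-2-yl on a double-bonded chain carbon bound to a double-bonded chain carbon, with 4-chlorophenyl in place of pyridin-2-yl on a double-bonded chain carbon bound to a double-bonded chain carbon. Within the data shown here, two measured steps bear on this exchange: an at least 1.5-fold lower number from compound 1 to compound 3 (0.17 log units; that floor lies within the scatter) and an at least 1.5-fold lower number from compound 2 to compound 3 (0.17 log units; that floor lies within the scatter). Compound 4 runs the same kind of exchange the other way, back to a substituted phenyl, so a small rise in this assay is expected, and a reading at the limit of > 10000 nM in this assay, at which 2 of the 3 values shown sit, would be no surprise. The expected change is a 1.7-fold higher number from compound 3 to compound 4 (0.22 log units; within the scatter). For compound 4 the estimated value is 11000 nM, with an expected range of 5000 nM to 25000 nM.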

Compound 4, half-maximal inhibitory concentration: > 10000 nM
Compound 4 gave a limit, no number; the forecaster's own chance of this, stated with the estimate: 60%; the middle value lies beyond the limit too.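

Replacing pyridin-2-yl with 4-chlorophenyl on a double-bonded chain carbon bound to a double-bonded chain carbon gives, in this assay, an at least 1.5-fold higher number from compound 3 to compound 4 (0.17 log units; that floor lies within the scatter). The steps among compound 1, compound 2 and compound 4 cannot be read, so chloro cannot be ranked against fluoro or hydrogen on the aromatic carbon. Compound 3 still holds the only number in the set, while the limit now covers a third phenyl-bearing compound: the limit of > 10000 nM in this assay, at which 3 of the 4 values shown sit.

Going by these compounds, it remains open whether pyridin-3-yl, pyridin-4-yl or a phenyl bearing an amine would give a number in this assay. On these data alone, the true size of the step to compound 4 also remains unknown.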